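Replacing thiophen-2-yl with 3,4,5-trimethoxyphenyl

The source may report more compounds than this note shows. Statements on the series, on what has been measured and on what is new or still open speak of the compounds shown alone.

Three measured compounds share one core and differ only in the group on a double-bonded chain carbon bound to a double-bonded chain carbon. In a functional assay, read by spectrophotometry, tested at 100 uM (on this read-out lower numbers stand for stronger inhibition and higher numbers for weaker inhibition), compound 3 `O=C(/C=C/c1cccs1)c1cccc(NC(=O)c2cc(-c3ccncc3)n[nH]2)c1` gives 27600 nM, the lowest of the three numbers. Compound 1 `O=C(/C=C/c1cccc2ccccc12)c1cccc(NC(=O)c2cc(-c3ccncc3)n[nH]2)c1` gives 64500 nM, and compound 2 `Cc1ccc(/C=C/C(=O)c2cccc(NC(=O)c3cc(-c4ccncc4)n[nH]3)c2)cc1` gives 69400 nM.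

Compound 4 `COc1cc(/C=C/C(=O)c2cccc(NC(=O)c3cc(-c4ccncc4)n[nH]3)c2)cc(OC)c1OC`, not yet measured, has 3,4,5-trimethoxyphenyl in place of the thiophen-2-yl of compound 3: 3,4,5-trimethoxyphenyl in place of thiophen-2-yl on a double-bonded chain carbon bound to a double-bonded chain carbon. Two measured steps ending at the thiophen-2-yl compound bear on this change: a 2.3-fold lower number from compound 1 to compound 3 (0.37 log units; beyond the scatter) and a 2.5-fold lower number from compound 2 to compound 3 (0.40 log units; beyond the scatter). Both are modest. The remaining step, a 1.1-fold higher number from compound 1 to compound 2 (0.03 log units; within the scatter), shows that exchanging the two carbon-only aromatic groups made little difference. Among the compounds with values here, no measured compound carries the entering group, so the comparison is only approximate. Leaving thiophen-2-yl is expected to reverse those modest steps, giving a higher number in this assay: the expected change is a 2.2-fold higher number from compound 3 to compound 4 (0.34 log units; beyond the scatter). For compound 4, the estimated value is 60000 nM, with an expected range from 28000 nM to 100000 nM.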

Compound 4, half-maximal inhibitory concentration: 54500 nM
The estimate for compound 4 lay 1.1-fold (0.04 log units) above the measured number; measured number inside the range.
By their numbers in this assay, from the lowest: compounds 3, 4, 1 and 2 (each within the scatter of the next, the first and the last beyond it).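

In this assay, 3,4,5-trimethoxyphenyl, with more heavy atoms and more hydrogen-bond acceptors, can stand in place of thiophen-2-yl on a double-bonded chain carbon bound to a double-bonded chain carbon, with a 2.0-fold higher number from compound 3 to compound 4 (0.30 log units; within the scatter). Against the two carbon-only groups at this place, the trimethoxy group shows no real difference either, with a 1.3-fold lower number from compound 2 to compound 4 (0.10 log units; within the scatter) and a 1.2-fold lower number from compound 1 to compound 4 (0.07 log units; within the scatter). Compound 4 therefore lies within the scatter of all three earlier compounds, so the numbers at this place no longer divide neatly into thiophen-2-yl against the rest.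

Going by these compounds, whether an aromatic ring carrying an amine or a carboxylic acid at this place would move the number beyond the scatter remains open. Nothing available explains how closely these groups read.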